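A Longer Chain on the Ring Oxygen: Compound 4

The compounds below may be only part of what the source reports. "The series", "measured", "known", "first", "only" and "open" are said of these compounds alone.

Three measured compounds share one core, shown in compound 1 `COc1cc(/C=C2\CCC/C(=C\c3ccccc3[N+](=O)[O-])C2=O)cc(Br)c1OC`. In a functional assay on MCF7 cells (Homo sapiens) for cytotoxicity, read by MTT assay (on this read-out lower numbers stand for stronger inhibition and higher numbers for weaker inhibition), compound 1 gives 3.35 ug/mL. Compound 2 `CCCOc1c(Br)cc(/C=C2\CCC/C(=C\c3ccccc3[N+](=O)[O-])C2=O)cc1OC` carries an ethyl group where compound 1 has a hydrogen, and in this assay compound 2 gives 4.14 ug/mL; the step is a 1.2-fold higher number from compound 1 to compound 2 (0.09 log units; within the scatter). Compound 3 `COc1cc(/C=C2\CCC/C(=C\c3cccc([N+](=O)[O-])c3)C2=O)cc(Br)c1OC` instead carries a 3-nitrophenyl group in place of the 2-nitrophenyl group of compound 1, and compound 3 gives 4.72 ug/mL, a step of a 1.4-fold higher number from compound 1 to compound 3 (0.15 log units; within the scatter). Compound 3 thus shows the highest of the three numbers, but its gaps to compound 2 and to compound 1 both lie within the scatter, so none of the three can be called stronger or weaker than another.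

Compound 4 `CCCCOc1c(Br)cc(/C=C2\CCC/C(=C\c3cccc([N+](=O)[O-])c3)C2=O)cc1OC` differs from compound 3 in a single spot: propyl in place of hydrogen on a saturated chain carbon bound to an oxygen on an aromatic ring. Among the measured compounds shown here, the one measured step that bears on this change is the one from compound 1 to compound 2, where the same kind of chain was added at the same place and a 1.2-fold higher number from compound 1 to compound 2 (0.09 log units; within the scatter) was found. The new chain is one carbon longer, and nothing measured here speaks to that extra carbon. A step of similar size, leaning if anything towards a slightly higher number, is therefore expected: a 1.1-fold higher number from compound 3 to compound 4 (0.04 log units; within the scatter). On that basis compound 4 is estimated at 5.2 ug/mL, with a range from 2.6 ug/mL to 10.5 ug/mL.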

Compound 4, half-maximal inhibitory concentration: 5.97 ug/mL
Compound 4: the middle estimate sits 1.1-fold (0.06 log units) below what was measured, and the stated range covers the measured number.
By their numbers in this assay, from the lowest: compounds 1, 2, 3 and 4 (each within the scatter of the next).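

Replacing methoxy with butoxy at this carbon on the ring oxygen gives a 1.3-fold higher number from compound 3 to compound 4 (0.10 log units; within the scatter) in this assay, so a chain of this length brings no change that can be read here. Until now this place had been probed only by the ethyl step on the 2-nitrophenyl compounds, which gave a 1.2-fold higher number from compound 1 to compound 2 (0.09 log units; within the scatter); the new step extends that picture to a longer chain and to compounds carrying 3-nitrophenyl, and in both pairs the number stays within the scatter. Nothing in the available data explains the size of either step.

As far as these compounds go, both chains tried at this place are plain carbon chains, so it remains open whether a much longer chain, such as decyl, would move the number beyond the scatter, or whether the same would happen with a chain ending in an amine or a carboxylic acid. It is also open what a hydroxyl group would do at this ring oxygen, with the chain removed altogether, since every compound shown keeps a carbon chain there.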